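Aryl enone acids: butyl on the aromatic carbon

The compounds below may be only part of what the source reports. "The series", "measured", "known", "first", "only" and "open" are said of these compounds alone.

Series notes. Two members are measured in a functional assay on HeLa cells (Homo sapiens) for inhibition, read by MTT assay, with a stated time of 72 h; on this read-out lower numbers stand for stronger inhibition and higher numbers for weaker inhibition. Compound 1 `O=C(O)/C=C/C(=O)c1ccccc1` gives 30600 nM, the lowest of the two numbers. Compound 2 `O=C(O)/C=C/C(=O)c1ccc(Cl)cc1Cl` gives 62900 nM, a higher number that lies beyond the scatter against compound 1. Compound 3 `CCCCc1ccc(C(=O)/C=C/C(=O)O)cc1` is still unmeasured; it differs from compound 1 by butyl in place of hydrogen on an aromatic carbon. Among the compounds with values here, no step between measured compounds of this kind is known, so the change has no measured precedent here; a small step toward a lower number is expected, if any beyond the scatter. Compound 3 is expected at 20000 nM, between 8000 nM and 60000 nM, which corresponds to an expected step of a 1.5-fold lower number from compound 1 to compound 3 (0.18 log units; within the scatter).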

Compound 3, half-maximal inhibitory concentration: 4780 nM
Compound 3: the middle estimate sits 4.2-fold (0.62 log units) above what was measured; the whole stated range lies above it.
By their numbers in this assay, from the lowest: compound 3; then compound 1; then compound 2.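

In this assay, within the data shown here, butyl in place of hydrogen on an aromatic carbon gives a 6.4-fold lower number from compound 1 to compound 3 (0.81 log units; beyond the scatter) and is the first measured step at this position of the series. The position, para to a group of 7 heavy atoms, therefore takes butyl with a lower number rather than a higher one. Nothing at hand bears on the reason for this step.
Whether the step follows chain length stays open, since only butyl is shown here and neither ethyl nor a longer chain such as octyl appears. From the compounds shown here alone, an amine or a carboxylic acid at this position is equally open.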